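Oxime ethers: methyl for trifluoromethyl on the benzyl ring

The compounds below may be only part of what the source reports. "The series", "measured", "known", "first", "only" and "open" are said of these compounds alone.

Measured so far in a functional assay on MKN-45 cells (Homo sapiens) for antiproliferative activity, tested at 1 uM; a lower number here means less inhibition, a higher number more inhibition at the concentration tested (going by the name of the read-out):
compound 1 `Cc1c(CO/N=C/c2c(-c3ccccc3)nn(-c3ccccc3)c2Oc2ccc(Cl)cc2)cccc1-c1ccccc1` gives -15%
compound 2 `Cc1nn(C)c(Oc2ccccc2)c1/C=N/OCc1ccc(C(F)(F)F)cc1` gives 11%
compound 3 `Cc1nn(C)c(Oc2ccc(Cl)cc2)c1/C=N/OCc1ccc(C(F)(F)F)cc1` gives 27.6%

Compound 2 stands second highest of the three numbers in this assay: compound 3 lies beyond the scatter above it, and compound 1 lies beyond the scatter below it. Going by the values given here, the only step within the set is a number 16.6 percentage points higher from compound 2 to compound 3 (beyond the scatter), a change on a different ring from the one altered here. Compound 4 `Cc1ccc(CO/N=C/c2c(C)nn(C)c2Oc2ccccc2)cc1` differs from compound 2 by methyl in place of trifluoromethyl on an aromatic carbon. Among the compounds with values here, no measured step bears on this change, so nothing in the set argues for a move beyond the scatter in either direction, and the expectation rests on compound 2 alone. Compound 4 is therefore estimated at 8%, with a range from -10% to 26%, which means an expected step of a number 3 percentage points lower from compound 2 to compound 4 (within the scatter).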

Compound 4, a percentage reported as inhibition, at one concentration (the size of the read-out at that concentration, not a potency): 17.9%
Compound 4: the middle estimate sits 9.9 percentage points below what was measured, and the stated range covers the measured number.
By their numbers in this assay, from the lowest: compound 1; then compounds 2, 4 and 3 (each within the scatter of the next, the first and the last beyond it).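

In this assay methyl in place of trifluoromethyl, para to a large group, gives a number 6.9 percentage points higher from compound 2 to compound 4 (within the scatter) and so this read-out does not separate the two groups at this position. Trifluoromethyl is therefore not needed here to retain the inhibition seen at this single concentration. No measurement available here offers an explanation for this result.

Open, from the compounds shown here alone, is whether a carboxylic acid, an amine or a nitrile at this position would move the number beyond the scatter. Also open, going by these compounds, is whether methyl matches trifluoromethyl when chloro is present, as in compound 3.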